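This account rests on a few compounds, and the source may have more. Where it says the series, first, only, none or still open, it means among the compounds named here.

Working notes on the series. Among the compounds with values here, compound 1 (`CNc1nc(Oc2ccccc2)cc(-c2ccccn2)n1`) carries a phenoxy group on the shared core; in a functional assay on CHO cells for agonist activity at G-protein coupled receptor 39 (Homo sapiens), read by calcium flux (a lower number here means that less compound is needed, a higher number that more compound is needed for the effect), compound 1 gives 481 nM, the only number in this assay so far. Compound 2 (`CNc1cc(-c2ccccn2)nc(NC2CCCCC2)n1`) arranges methylamino and cyclohexylamino differently on the same core and is not a one-place neighbour of compound 1. In this assay compound 2 gives > 31600 nM, which is a limit of the assay and not a number. Within the data shown here, the remaining information is the limit of > 31600 nM in this assay, at which 1 of the 2 values shown sits, so no measured step between two compounds exists.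

Compound 3 (`CNc1nc(NC2CCCCC2)cc(-c2ccccn2)n1`) is the direct neighbour of compound 1: the change is cyclohexylamino in place of phenoxy on an aromatic carbon. Among the measured compounds shown here, no comparable step has been measured, so the size of the effect is open. The expected step from compound 1 to compound 3 in this assay is a 4.2-fold higher number from compound 1 to compound 3 (0.62 log units; beyond the scatter), a loss beyond the scatter, with the outcome uncertain in both directions. Compound 3 is estimated at 2000 nM, within 400 nM to 15000 nM.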

Compound 3, half-maximal effective concentration: 16 nM
Compound 3: middle estimate off by 130-fold (2.10 log units), on the high side; the measured number lies below the stated range.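

At this position, on an aromatic carbon opposite the ring nitrogen, the series now has its first measured step: in this assay, cyclohexylamino in place of phenoxy gives a 30-fold lower number from compound 1 to compound 3 (1.48 log units; beyond the scatter), so an aromatic ring of carbon is not needed here for a low number. The change replaces an aromatic ring with a non-aromatic one and at the same time exchanges the oxygen for a nitrogen that brings a hydrogen-bond donor, and this single step does not separate these differences. Compound 2 holds the same two amino groups in a different arrangement and is not a one-place neighbour of compound 3, so it supplies no step, and its value remains a limit of the assay and not a number: the limit of > 31600 nM in this assay, at which 1 of the 3 values shown sits.

Going by these compounds, it remains open whether the ring or the linking atom accounts for the step; phenylamino and cyclohexyloxy at this position would separate the two. Also open, on these data alone, is how much of the ring is needed, which a smaller cyclopentylamino group or a piperidin-1-yl group, without the amine hydrogen, would begin to show.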